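Carboxylate for nitro on the aryl-triazole side chain

The source may report more compounds than this note shows. Statements on the series, on what has been measured and on what is new or still open speak of the compounds shown alone.

Three compounds built on a shared bicyclic core carry a triazole whose nitrogen substituent varies. Compound 1, `O=C1C[C@H](OCc2cn(Cc3ccccc3)nn2)[C@H]2CO[C@@H]1O2`, bears a benzyl group; in a functional assay on MDA-MB-231 cells (Homo sapiens) for cytotoxicity, read by MTT assay, with a stated time of 48 h (on this read-out higher numbers stand for weaker inhibition and lower numbers for stronger inhibition), compound 1 reaches only the assay limit of > 50000 nM. Compound 2, `O=C1C[C@H](OCc2cn(C(=O)c3ccccc3)nn2)[C@H]2CO[C@@H]1O2`, carries a benzoyl group instead, and in this assay compound 2 gives 25900 nM; the change an at least 1.9-fold lower number from compound 1 to compound 2 (0.28 log units; that floor lies within the scatter) rests on the limit (the limit of > 50000 nM in this assay, at which 1 of the 3 values shown sits). Compound 3, `O=C1C[C@H](OCc2cn(-c3ccc([N+](=O)[O-])cc3)nn2)[C@H]2CO[C@@H]1O2`, carries a nitrophenyl group, and in this assay compound 3 gives 24800 nM, which sits within the scatter of compound 2.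

Compound 4, `O=C(O)c1ccc(-n2cc(CO[C@H]3CC(=O)[C@@H]4OC[C@H]3O4)nn2)cc1`, differs from compound 3 by carboxy in place of nitro on an aromatic carbon. For the measured compounds named here, no measured step touches the substituent on this phenyl ring; the only measured step, from a benzyl to a benzoyl group on nitrogen, stayed at the edge of the scatter. With nothing to suggest a shift in either direction, compound 4 is expected in this assay to give about 28000 nM, estimated between 10000 nM and 60000 nM, so that the expected step of a 1.1-fold higher number from compound 3 to compound 4 (0.05 log units; within the scatter) stays within the scatter.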

Compound 4, half-maximal inhibitory concentration: 23200 nM
The estimate for compound 4 lay 1.2-fold (0.08 log units) above the measured number; low and high end bracket the measured number.
By their numbers in this assay, from the lowest: compounds 4, 3 and 2 (each within the scatter of the next). At a limit, above all of these: compound 1.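

In this assay, for the compounds shown here, carboxy in place of nitro on the aromatic carbon para to a large group gives a 1.1-fold lower number from compound 3 to compound 4 (0.03 log units; within the scatter), the first measured step at this position. Carboxy brings a hydrogen-bond donor that nitro lacks, yet compound 3 and compound 4 cannot be told apart, so within this pair the exchange leaves the read-out inside the usual scatter. Nothing measured here offers a reason for this.

The compounds shown leave open whether an amine, a methoxy group or a longer chain at this position would give a step beyond the scatter. They also leave open whether a methyl ester or an amide in place of carboxy would read any differently in this assay.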